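A few compounds are considered here, and "the series" means these few. Any claim that something is new, unique, unknown or untested is made for them only; others in the source may bear on it.

Within the data shown here, three related compounds have numbers so far in a functional assay on KYSE-450 cells (Homo sapiens) for inhibition, read by MTT assay, with a stated time of 48 h; a higher number here means a weaker inhibitor, a lower number a stronger inhibitor. Compound 1 `C/C=C/C(=O)N(Cc1ccc(OC)c([N+](=O)[O-])c1)c1cc(OC)c(OC)c(OC)c1` gives 510 nM, compound 3 `COCC(=O)N(Cc1ccc(OC)c(O)c1)c1cc(OC)c(OC)c(OC)c1` gives 460 nM, and compound 2 `COc1ccc(CNc2cc(OC)c(OC)c(OC)c2)cc1[N+](=O)[O-]` gives 16800 nM, the highest of the three and so the weakest inhibitor here.

The compound still unmeasured, compound 4 `COc1ccc(CNc2cc(OC)c(OC)c(OC)c2)cc1N`, differs from compound 2 in one place: amino in place of nitro on an aromatic carbon, ortho to a methoxy group (amino in place of nitro on an aromatic carbon).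

Among the measured compounds shown here, no measured step changes this group, so nothing shows directly what the swap will do. For the measured compounds named here, the only measured step, a 33-fold higher number from compound 1 to compound 2 (1.52 log units; beyond the scatter), puts hydrogen in place of (prop-1-en-1-yl)carbonyl on a nitrogen, which is a different place in the molecule. That step shows only that a single change among these compounds can move the number a long way, and it gives no direction for the present change.

Compound 2 stands at the top of the range seen, with 16800 nM, so a moderate fall in the number is expected rather than a rise, though nothing measured settles this. The estimated step is a 3.4-fold lower number from compound 2 to compound 4 (0.53 log units; beyond the scatter). For compound 4 the estimated value is 5000 nM, with an expected range from 800 nM to 25000 nM.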

Compound 4, half-maximal inhibitory concentration: 2210 nM
For compound 4 the middle estimate is 2.3-fold (0.35 log units) above the measured one; the range from low to high includes it.
By their numbers in this assay, from the lowest: compounds 3 and 1 (each within the scatter of the next); then compound 4; then compound 2.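

Amino in place of nitro, on an aromatic carbon ortho to a methoxy group, gives a 7.6-fold lower number from compound 2 to compound 4 (0.88 log units; beyond the scatter) in this assay, so the group at this position affects inhibition, and here the amino compound is the stronger inhibitor. The change is modest beside the large step at the ring-bound nitrogen, a 33-fold higher number from compound 1 to compound 2 (1.52 log units; beyond the scatter), yet it shows that a second place in these molecules can also move the number by more than the usual scatter. Nothing available here accounts for why this swap lowers the number.

From the compounds shown here alone, this single pair carries a hydrogen on the nitrogen, so it remains open whether amino in place of nitro would do the same with the (prop-1-en-1-yl)carbonyl group of compound 1 on that nitrogen. Going by these compounds, it is also open how other groups at this position, such as a nitrile, a fluorine or an acetylamino group, would compare with amino and nitro, and how far the number can fall with a change at this carbon alone.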